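Amide substituent variation on the shared core

The compounds below may be only part of what the source reports. "The series", "measured", "known", "first", "only" and "open" are said of these compounds alone.

Compound 3 `COc1ccc(CN(C(=O)CN=[N+]=[N-])c2cc(OC)c(OC)c(OC)c2)cc1O` gives 160 nM in a functional assay on KYSE-450 cells (Homo sapiens) for inhibition, read by MTT assay, with a stated time of 48 h (on this read-out higher numbers stand for weaker inhibition and lower numbers for stronger inhibition), the second highest of three numbers. Compound 1 `C=C(C)C(=O)N(Cc1ccc(OC)c(O)c1)c1cc(OC)c(OC)c(OC)c1` lies nearest with 200 nM (a 1.3-fold lower number from compound 1 to compound 3 (0.10 log units; within the scatter)). Compound 2 `CCC/C=C/C(=O)N(Cc1ccc(OC)c(O)c1)c1cc(OC)c(OC)c(OC)c1` lies furthest with 57 nM (a 2.8-fold higher number from compound 2 to compound 3 (0.45 log units; beyond the scatter)). The next change gives compound 4 `COc1ccc(CN(C(=O)C(C)C)c2cc(OC)c(OC)c(OC)c2)cc1O`: isopropyl in place of azidomethyl on a carbonyl carbon. Among the measured compounds shown here, no measured step introduces isopropyl; the steps on this carbonyl carbon are a 3.5-fold lower number from compound 1 to compound 2 (0.55 log units; beyond the scatter), a 1.3-fold lower number from compound 1 to compound 3 (0.10 log units; within the scatter) and a 2.8-fold higher number from compound 2 to compound 3 (0.45 log units; beyond the scatter), the two larger ones involving pent-1-en-1-yl. Exchanging one small group for another here, 1-methylethenyl for azidomethyl, moved the number only within the scatter (a 1.3-fold lower number from compound 1 to compound 3 (0.10 log units; within the scatter)), so another small group is expected to do likewise. Compound 4 is therefore estimated at 190 nM, between 80 nM and 450 nM, an expected step of a 1.2-fold higher number from compound 3 to compound 4 (0.07 log units; within the scatter).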

Compound 4, half-maximal inhibitory concentration: 390 nM
For compound 4 the middle estimate is 2.1-fold (0.31 log units) below the measured one; measured number inside the range.
By their numbers in this assay, from the lowest: compound 2; then compounds 3, 1 and 4 (each within the scatter of the next, the first and the last beyond it).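

On this carbonyl carbon, a small-for-small exchange is not always silent: a 2.4-fold higher number from compound 3 to compound 4 (0.39 log units; beyond the scatter) lies beyond the scatter, whereas a 2.0-fold higher number from compound 1 to compound 4 (0.29 log units; within the scatter) stays within it. Among the compounds shown here, the largest step so far, a 6.8-fold higher number from compound 2 to compound 4 (0.84 log units; beyond the scatter), leaves pent-1-en-1-yl as the only group here whose number is separated from all three others. No measurement at hand accounts for these steps. Open, as far as these compounds go, is whether a saturated pentyl chain matches pent-1-en-1-yl, and how an amine or a carboxylic acid would read on this carbonyl carbon.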